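Swapping Chloro for Methyl on Compound 2

The source may report more compounds than this note shows. Statements on the series, on what has been measured and on what is new or still open speak of the compounds shown alone.

Of the compounds shown here, two have so far been measured in a functional assay on HT-29 cells (Homo sapiens) for cytotoxicity, read by MTT assay, with a stated time of 72 h; on this read-out higher numbers stand for weaker inhibition and lower numbers for stronger inhibition. Compound 1 `Cc1ccc(NC(=O)Nc2ccc(-c3nc(NCCN(C)C)c4sccc4n3)cc2)cc1` gives 2150 nM in this assay. Compound 2 `CCN(CC)CCCNc1nc(-c2ccc(NC(=O)Nc3ccc(Cl)cc3)cc2)nc2ccsc12` gives 58 nM in this assay, the lower of the two numbers, with compound 1 a long way higher and beyond the usual scatter. These two compounds differ in more than one place, so their gap cannot be tied to a single change.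

Compound 3 `CCN(CC)CCCNc1nc(-c2ccc(NC(=O)Nc3ccc(C)cc3)cc2)nc2ccsc12` is compound 2 with one change: methyl in place of chloro on an aromatic carbon. For the measured compounds named here, no measured pair shows this change on its own. Compound 1, which also carries methyl rather than chloro, gives the weaker value 2150 nM, though its amine chain differs too. The expected step is therefore a 3.4-fold higher number from compound 2 to compound 3 (0.54 log units; beyond the scatter). Compound 3 is estimated at 200 nM, within a range from 60 nM to 800 nM.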

Compound 3, half-maximal inhibitory concentration: 1620 nM
Compound 3: middle estimate off by 8.1-fold (0.91 log units), on the low side; measured number above the stated range.
By their numbers in this assay, from the lowest: compound 2; then compounds 3 and 1 (each within the scatter of the next).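

In this assay, methyl in place of chloro on the aromatic carbon para to a large group gives a 28-fold higher number from compound 2 to compound 3 (1.45 log units; beyond the scatter), so this one swap of a single heavy atom, with no change in hydrogen-bond donors or acceptors, separates the two compounds by well beyond the scatter. With methyl at this position, the change in the amine chain gives a 1.3-fold lower number from compound 1 to compound 3 (0.12 log units; within the scatter), which lies within the scatter, so that chain change shows no clear effect here. Nothing shown accounts for the large gap between chloro and methyl.

Going by these compounds, whether the chain matters when chloro occupies this position remains open. So does how other groups would compare here, such as fluoro, bromo, methoxy or trifluoromethyl, and whether chloro stands out among them.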